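Lengthening the ether chain: from compound 2 to compound 3

The source may report more compounds than this note shows. Statements on the series, on what has been measured and on what is new or still open speak of the compounds shown alone.

Of the compounds shown here, two sharing one core have been measured in an assay on HEK293 cells for agonist activity at transient receptor potential cation channel subfamily M member 8 (Homo sapiens), read by fluorescence and calcium flux, with a stated time of 5 min; a lower number here means that less compound is needed, a higher number that more compound is needed for the effect. Compound 1 `C=CCc1cc(OC)c(OC(C)C(OCCOCCCC)c2ccc(O)c(OC)c2)c(OC)c1` gives 153 nM, and compound 2 `C=CCc1cc(OC)c(OC(C)C(OCC)c2ccc(O)c(OC)c2)c(OC)c1` gives 332 nM. Compound 2 therefore stands at the higher of the two numbers, a step of a 2.2-fold higher number from compound 1 to compound 2 (0.34 log units; beyond the scatter), so removing the butoxy end of the chain raised the number. Compound 3 `C=CCc1cc(OC)c(OC(C)C(OCCCCCC)c2ccc(O)c(OC)c2)c(OC)c1` is the unmeasured compound, and its change from compound 2 is butyl in place of hydrogen on a saturated chain carbon, two bonds along the chain from an oxygen on a saturated carbon; read one bond further out, this is ethoxy becoming hexyloxy. Among the measured compounds shown here, the only step that bears on it is the one from compound 1 to compound 2, in which a chain of comparable reach was cut back and the number rose. Restoring a chain of that reach in compound 3 is expected to bring the number back down, by a 1.8-fold lower number from compound 2 to compound 3 (0.27 log units; within the scatter). Compound 3 is estimated at 180 nM, within 80 nM to 400 nM.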

Compound 3, half-maximal effective concentration: 329 nM
The estimate for compound 3 lay 1.8-fold (0.26 log units) below the measured number, and the stated range covers the measured number.
By their numbers in this assay, from the lowest: compound 1; then compounds 3 and 2 (each within the scatter of the next).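

In this assay, ethoxy and hexyloxy at this saturated chain carbon give numbers within the scatter of each other (a 1.0-fold lower number from compound 2 to compound 3 (0.00 log units; within the scatter)), so adding butyl in place of hydrogen does not by itself reproduce the lower number of compound 1. Compound 3 differs from compound 1 by butyl in place of butoxy, a step beyond the scatter (a 2.2-fold higher number from compound 1 to compound 3 (0.33 log units; beyond the scatter)), so at this position the two chains of comparable reach are not interchangeable. Nothing given here accounts for that difference.

Whether the gap follows from the oxygen within the chain of compound 1, from where that oxygen sits, or from its butoxy end stays open with only three chains shown. So does how a longer chain such as octyloxy, or a chain ending in an amine or a carboxylic acid, would read at this position.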